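The source may hold more compounds than are shown below. What is called first, only, known or untested is meant among the compounds shown, and "the series" means these compounds.

Measured in a physicochemical assay for solubility; a lower number here means a less soluble compound, a higher number a more soluble compound:
- compound 1 `O=C(Nc1ccc(C(F)(F)F)cc1)c1cc(Cl)ccc1O`: < 1 ug/mL
- compound 2 `O=C(Nc1ccc(C(F)(F)F)cc1)c1cc(Br)ccc1O`: < 1 ug/mL

Not yet measured: compound 3 `O=C(Nc1ccc(C(F)(F)F)c(F)c1)c1cc(Br)ccc1O`.

Compound 2 stands at < 1 ug/mL, which is a limit and not a number. Within the data shown here, the same holds for compound 1, and the series so far shows (the limit of < 1 ug/mL in this assay, at which 2 of the 2 values shown sit). The change to compound 3 is fluoro in place of hydrogen on an aromatic carbon, ortho to a trifluoromethyl group. Among the measured compounds shown here, the only measured step is a step that the two limits leave unreadable from compound 1 to compound 2, so it offers no size to carry over. No step beyond the scatter is expected in this assay, and the expected step is a step that the limit leaves unreadable from compound 2 to compound 3. The estimate for compound 3 is 0.6 ug/mL, with an expected range of 0.2 ug/mL to 1.5 ug/mL.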

Compound 3, solubility: < 1 ug/mL
Compound 3: a limit, no number; the forecaster's own chance of this, stated with the estimate: 85%; the middle value lies beyond the limit too.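

Among these compounds, compound 2 and compound 3 both stand at a limit and not a number, and no step between them can be read in this assay. As far as these compounds go, the actual values of compound 1, compound 2 and compound 3 remain open, as does any effect of fluoro in place of hydrogen.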